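Removing the ortho-fluoro from compound 2

The compounds below may be only part of what the source reports. "The series", "measured", "known", "first", "only" and "open" are said of these compounds alone.

Measured compounds: compound 1 `Cc1cccc(S(=O)(=O)Nc2cccc(-c3ccc(C(=O)c4cc(F)c(F)c(O)c4F)s3)c2)c1`, 0.2 nM; compound 2 `O=C(c1ccc(-c2cccc(NS(=O)(=O)c3ccccc3)c2)s1)c1c(F)ccc(O)c1Cl`, 6.7 nM.

In an assay on microsomes from placenta for inhibition of 17-beta-hydroxysteroid dehydrogenase type 2 (Homo sapiens), read by HPLC, in the presence of a further agent that is not named here (a lower number here means a stronger inhibitor, a higher number a weaker inhibitor), compound 2 gives the higher of the two numbers; compound 1 gives 0.2 nM, a gap beyond the scatter. Compound 3 `O=C(c1ccc(-c2cccc(NS(=O)(=O)c3ccccc3)c2)s1)c1cccc(O)c1Cl` is not yet measured. It differs from compound 2 by hydrogen in place of fluoro on an aromatic carbon, the position being ortho to the carbonyl and para to the hydroxy group. Going by the values given here, with no measured pair of this kind, a modest weakening is expected, perhaps within or just beyond the scatter: a 2.2-fold higher number from compound 2 to compound 3 (0.35 log units; beyond the scatter). Compound 3 is thus estimated at 15 nM, range 4 nM to 60 nM.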

Compound 3, half-maximal inhibitory concentration: 0.9 nM
For compound 3 the middle estimate is 17-fold (1.22 log units) above the measured one; the measured number lies below the stated range.
By their numbers in this assay, from the lowest: compound 1; then compound 3; then compound 2.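

In this assay, the change from 2-chloro-6-fluoro-3-hydroxyphenyl to 2-chloro-3-hydroxyphenyl gives a 7.4-fold lower number from compound 2 to compound 3 (0.87 log units; beyond the scatter). The fluoro at this position is therefore not required for strong inhibition in this pair, and hydrogen is the better of the two groups here. Nothing at hand accounts for the size or direction of this step. Still open, from the compounds shown here alone, is how an amine or a methoxy group would compare with hydrogen at this position. Also open, going by these compounds, is whether hydrogen in place of fluoro gives a similar step elsewhere.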